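Chloro to pyridinylamino on the shared core

The source may report more compounds than this note shows. Statements on the series, on what has been measured and on what is new or still open speak of the compounds shown alone.

Compound 1 `N#Cc1c(Cl)nc(SCc2nc3ccccc3[nH]2)nc1-c1ccccc1` is one of two measured members of this series. Going by the values given here, in a functional assay on SK-OV-3 cells (Homo sapiens) for cytotoxicity, read by MTT assay, with a stated time of 3 days (a lower number here means a stronger inhibitor, a higher number a weaker inhibitor), compound 1 gives 3.37 nM, which is the higher of the two numbers, but its only neighbour sits within the scatter: compound 2 `CNc1nc(SCc2nc3ccccc3[nH]2)nc(-c2ccccc2)c1C#N` gives 3 nM, and the step from compound 1 to compound 2, methylamino in place of chloro on an aromatic carbon, amounts to a 1.1-fold lower number from compound 1 to compound 2 (0.05 log units; within the scatter).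

Compound 3 `N#Cc1c(Nc2ccccn2)nc(SCc2nc3ccccc3[nH]2)nc1-c1ccccc1` has not yet been measured. It differs from compound 1 by (pyridin-2-yl)amino in place of chloro on an aromatic carbon. Among the compounds with values here, the only measured step that bears on this change is the one from compound 1 to compound 2, where an amino-type group likewise replaced the chloro at the same aromatic carbon and the number barely moved. Within the data shown here, no measured compound carries a group as large as (pyridin-2-yl)amino at this position, so the data give no guidance on that size. Compound 3 is therefore expected to show a step of about a 1.2-fold higher number from compound 1 to compound 3 (0.07 log units; within the scatter), that is no change beyond the scatter, with the larger group allowing a somewhat wider range. The estimate for compound 3 is 4 nM, between 1.5 nM and 12 nM.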

Compound 3, half-maximal inhibitory concentration: 5.81 nM
Compound 3: middle estimate off by 1.5-fold (0.16 log units), on the low side; low and high end bracket the measured number.
By their numbers in this assay, from the lowest: compounds 2, 1 and 3 (each within the scatter of the next).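

At the aromatic carbon ortho to a cyano group, a substituent of 7 heavy atoms with one six-membered aromatic ring, (pyridin-2-yl)amino, replaces chloro with its 1 heavy atom, and in this assay the result remains within the scatter (a 1.7-fold higher number from compound 1 to compound 3 (0.24 log units; within the scatter)). Exchanging methyl for pyridin-2-yl on the nitrogen of the amino substituent also stays within the scatter (a 1.9-fold higher number from compound 2 to compound 3 (0.29 log units; within the scatter)), so compounds 1, 2 and 3 cannot be separated in this assay, and the earlier finding now extends from methylamino to an amino group carrying an aromatic ring. No measurement available here accounts for this lack of separation.

Going by these compounds, it remains open whether a group of a different kind at this position would give a step beyond the scatter, for example a primary amine, morpholine, a carboxylic acid or a longer alkylamino chain. Anilino would test whether the ring nitrogen of the pyridin-2-yl group matters, and 3-pyridinylamino or 4-pyridinylamino would test whether its location in the ring does.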